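A ring in place of a branched chain on the shared core

The source may report more compounds than this note shows. Statements on the series, on what has been measured and on what is new or still open speak of the compounds shown alone.

Compound 1, `CCCOc1nc(N)nc2[nH]cnc12`, in an assay on HT-29 cells with Methylated-DNA--protein-cysteine methyltransferase (Homo sapiens) as the target (on this read-out higher numbers stand for weaker inhibition and lower numbers for stronger inhibition), gives > 1000000 nM, which is a limit of the assay.
Compound 2, `CC(C)CCOc1nc(N)nc2[nH]cnc12`, in this assay gives > 1000000 nM, which is also a limit of the assay.

Compound 2 therefore stands at the edge of what this assay can report, and compound 1 stands there too. Among the measured compounds shown here, the only measured step, a step that the two limits leave unreadable from compound 1 to compound 2, is unreadable in size, since both of its ends sit at the limit of > 1000000 nM in this assay, at which 2 of the 2 values shown sit. Compound 3, `Nc1nc(OCC2CCCC2)c2nc[nH]c2n1`, differs from compound 2 by cyclopentyl in place of isobutyl on a saturated chain carbon bound to an oxygen on an aromatic ring. For the measured compounds named here, the one step that bears on this change is the step from compound 1 to compound 2, and it gives no readable size, so no direction can be taken from it. With both measured compounds at the limit, the expectation for compound 3 is that it most likely remains at the limit as well, and the step of a number no higher from compound 2 to compound 3 (the limit leaves the size open) is expected to be nothing that can be read beyond the scatter. Compound 3 is thus estimated at 1000000 nM, within a range from 100000 nM to 1000000 nM.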

Compound 3, half-maximal inhibitory concentration: > 1000000 nM
Compound 3: no number, only a limit; the forecaster's own chance of this, stated with the estimate: 70%; the middle value sits exactly at the limit.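

In this assay compound 3 gives > 1000000 nM, which is a limit of the assay. The steps from compound 1 and compound 2 to compound 3 therefore cannot be read: the limit of > 1000000 nM in this assay, at which 3 of the 3 values shown sit.

The compounds shown leave open whether cyclopentyl, isobutyl and the chain of compound 1 differ at all in their inhibition.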